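The source may hold more compounds than are shown below. What is called first, only, known or untested is meant among the compounds shown, and "the series" means these compounds.

Measured compounds:
compound 1, `Cc1cc(S(=O)(=O)/N=C(\N)n2nccc2-c2ccccc2)c(SCc2ccc(Cl)cc2)cc1Cl`, giving 12000 nM in an ADME assay on HaCaT cells (Homo sapiens) for cytotoxicity, read by MTT assay, with a stated time of 72 h; on this read-out higher numbers stand for weaker inhibition and lower numbers for stronger inhibition
compound 2, `Cc1cccc(CSc2cc(Cl)c(C)cc2S(=O)(=O)/N=C(\N)n2nccc2-c2ccccc2)c1`, giving 10000 nM in this assay
compound 3, `Cc1cc(S(=O)(=O)/N=C(\N)n2nccc2-c2ccccc2)c(SCc2cccc(Cl)c2)cc1Cl`, giving 10000 nM in this assay

Compound 1 stands at the highest of the three numbers shown, but its nearest neighbour is compound 2 at a 1.2-fold lower number from compound 1 to compound 2 (0.08 log units; within the scatter), and its furthest is compound 3 at a 1.2-fold lower number from compound 1 to compound 3 (0.08 log units; within the scatter), so the three compounds lie together within the scatter of this assay and no ordering among them can be read. Compound 2 against compound 3 shows no change at the digits printed from compound 2 to compound 3 (within the scatter).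

Compound 4 is `Cc1cc(S(=O)(=O)/N=C(\N)n2nccc2-c2ccccc2)c(SCc2cccc(C(F)(F)F)c2)cc1Cl`. It differs from compound 1 in one place: 3-(trifluoromethyl)phenyl in place of 4-chlorophenyl on a saturated chain carbon bound to a sulfur.

Among the measured compounds shown here, two measured steps bear on this change, since both alter the group on the same saturated chain carbon bound to a sulfur of compound 1: a 1.2-fold lower number from compound 1 to compound 2 (0.08 log units; within the scatter) and a 1.2-fold lower number from compound 1 to compound 3 (0.08 log units; within the scatter). Each is within the scatter. The third step, no change at the digits printed from compound 2 to compound 3 (within the scatter), sits on an aromatic carbon elsewhere and is also within the scatter. Nothing among these compounds suggests that swapping the aryl group on that carbon moves the read-out of this assay beyond the scatter in either direction.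

Compound 4 is therefore expected to show a 1.1-fold lower number from compound 1 to compound 4 (0.04 log units; within the scatter), with an estimate of 11000 nM and a range of 5000 nM to 25000 nM in this assay.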

Compound 4, half-maximal inhibitory concentration: 18000 nM
The estimate for compound 4 lay 1.6-fold (0.21 log units) below the measured number, within the range that was stated.
By their numbers in this assay, from the lowest: compounds 2, 3, 1 and 4 (each within the scatter of the next).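

In this assay, 3-(trifluoromethyl)phenyl in place of 4-chlorophenyl on a saturated chain carbon bound to a sulfur gives a 1.5-fold higher number from compound 1 to compound 4 (0.18 log units; within the scatter) and so adds a third substituent on the aryl ring, and a group with more heavy atoms, without a step that leaves the scatter. Trifluoromethyl in place of chloro on an aromatic carbon gives a 1.8-fold higher number from compound 3 to compound 4 (0.26 log units; within the scatter) and replacing methyl with trifluoromethyl on an aromatic carbon gives a 1.8-fold higher number from compound 2 to compound 4 (0.26 log units; within the scatter), and these two are the largest steps among the four compounds, yet all of them remain within the scatter, so the four compounds still form one group with no order that can be read. No measurement shown here offers an account of these small steps.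

As far as these compounds go, all four compounds carry a benzyl group with a chloro, methyl or trifluoromethyl substituent on the same core, so it remains open whether an amine or a carboxylic acid on that ring would move the number in this assay beyond the scatter. From the compounds shown here alone, it is equally open whether a longer chain in place of the saturated chain carbon bound to a sulfur would do so, or whether any change to the shared core would.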